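The source may hold more compounds than are shown below. What is called first, only, known or untested is meant among the compounds shown, and "the series" means these compounds.

Compound 1 `CNC(=O)CCCCCCCn1nc(-c2cnc3[nH]ccc3c2)c2c(N)ncnc21` is the anchor of this set. For the measured compounds named here, in a functional assay on MDA-MB-231 cells (Homo sapiens) for inhibition, read by MTT assay, with a stated time of 72 h (on this read-out higher numbers stand for weaker inhibition and lower numbers for stronger inhibition), compound 1 gives 15800 nM, and this is the only firm number among the three measured compounds. Compound 2 `Nc1ncnc2c1c(-c1cnc3[nH]ccc3c1)nn2CCCCC(=O)NO` in this assay gives > 50000 nM, which is a limit. Compound 3 `Nc1ncnc2c1c(-c1cnc3[nH]ccc3c1)nn2CCCCCC(=O)NO` in this assay gives > 100000 nM, which is also a limit.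

Compound 4 `Nc1ncnc2c1c(-c1cnc3[nH]ccc3c1)nn2CCCC(=O)NO` has not yet been measured. It differs from compound 1 in one place: hydroxycarbamoyl in place of 4-(methylcarbamoyl)butyl on a saturated chain carbon, three bonds along the chain from an aromatic nitrogen. Going by the values given here, two measured steps bear on this change, since each makes the same kind of exchange cut one bond further out along the chain. The first gave an at least 3.1-fold higher number from compound 1 to compound 2 (0.50 log units; beyond the scatter). The second gave an at least 6.3-fold higher number from compound 1 to compound 3 (0.80 log units; beyond the scatter). Both steps run toward weaker inhibition, and both end at a limit of the assay, namely the limit of > 50000 nM in this assay, at which 1 of the 3 values shown sits, and (the limit of > 100000 nM in this assay, at which 1 of the 3 values shown sits), so their true size is not known.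

The change to compound 4 is therefore expected to weaken inhibition as well, with a step of about a 3.8-fold higher number from compound 1 to compound 4 (0.58 log units; beyond the scatter). For compound 4 in this assay the estimate is 60000 nM, with a range from 20000 nM to 200000 nM, and a real chance that only a limit is reported.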

Compound 4, half-maximal inhibitory concentration: > 150000 nM
Compound 4: only a limit was reported (the forecaster's own chance of this, stated with the estimate: 65%); at least 2.5-fold (0.39 log units) between middle value and limit.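

In this assay, the exchange of 4-(methylcarbamoyl)butyl for hydroxycarbamoyl, on a saturated chain carbon, three bonds along the chain from an aromatic nitrogen, gives an at least 9.4-fold higher number from compound 1 to compound 4 (0.97 log units; beyond the scatter). The weakening seen with compound 2 and compound 3 therefore also holds for compound 4, whose chain ending in hydroxycarbamoyl is shorter than theirs: none of the three compounds carrying hydroxycarbamoyl gives a firm number, and this shorter chain brings no measurable inhibition back. As far as these compounds go, the true size of the step stays unknown because compound 4 gives only a limit: the limit of > 150000 nM in this assay, at which 1 of the 4 values shown sits.

The values of compound 2, compound 3 and compound 4 are all limits and the steps among them cannot be read, which leaves open whether chain length matters at all within this group. Also open, from the compounds shown here alone, is what a longer chain ending in hydroxycarbamoyl, as long as the chain of compound 1, or a carboxylic acid at the chain end would give in this assay.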